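The source may report more compounds than this note shows. Statements on the series, on what has been measured and on what is new or still open speak of the compounds shown alone.

Compound 1 `Nc1ncnc2c1ncn2C[C@@H]1C[C@H](O)c2ccccc21` in an ADME assay on L1210/0 cells (Mus musculus) for cytotoxicity, with a stated time of 48 h (on this read-out higher numbers stand for weaker inhibition and lower numbers for stronger inhibition), gives > 200000 nM, a limit of the assay and not a number. Compound 2 `O[C@H]1C[C@@H](Cn2cnc3c(Cl)ncnc32)c2ccccc21` in this assay gives > 200000 nM, also a limit. Within the data shown here, compound 3 `CC1(C)[C@@H](Cn2nnc3c(Cl)nc(N)nc32)CC[C@@]1(C)CO` in this assay gives 44600 nM, the only number among the three.

The change from compound 2 to compound 1 is amino in place of chloro on an aromatic carbon, and the step it made is a step that the two limits leave unreadable from compound 2 to compound 1; its size cannot be read because of the limit of > 200000 nM in this assay, at which 2 of the 3 values shown sit. How the core of compound 3 differs from the core of compound 2 is not broken down here. Compound 4 `CC1(C)[C@@H](Cn2nnc3c(N)nc(N)nc32)CC[C@@]1(C)CO` carries the same kind of change against compound 3, (amino in place of chloro on an aromatic carbon), with the place differing in that it is meta to an amino group (1 heavy atom). With no readable earlier step, the step is estimated as a 2.0-fold higher number from compound 3 to compound 4 (0.30 log units; within the scatter), resting on compound 3 at 44600 nM. Compound 4 is expected to give about 90000 nM, between 30000 nM and 300000 nM.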

Compound 4, half-maximal inhibitory concentration: > 200000 nM
Compound 4: a limit, no number (the forecaster's own chance of this, stated with the estimate: 40%); at least 2.2-fold (0.34 log units) between middle value and limit.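

In this assay, amino in place of chloro on an aromatic carbon gives an at least 4.4-fold higher number from compound 3 to compound 4 (0.65 log units; beyond the scatter). The value of compound 4, > 200000 nM, is a limit of the assay and not a number. Whether the change carries from one core to another is not shown, because its step from the core of compound 2 cannot be read: the limit of > 200000 nM in this assay, at which 3 of the 4 values shown sit.

The compounds shown leave open how a methylamino or a methoxy group in place of chloro would read on the core of compound 3, the only core here with a measured number. They also leave open whether either group would bring the core of compound 2 to a readable value in this assay.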